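A few compounds are considered here, and "the series" means these few. Any claim that something is new, unique, unknown or untested is made for them only; others in the source may bear on it.

Four compounds are compared here, built on two closely related cores that carry the same group on an amide-type nitrogen in a ring or, in two of them, an isopropyl in its place. In a functional assay on A-375 cells (Homo sapiens) for antiproliferative activity, read by MTT assay, with a stated time of 72 h (on this read-out higher numbers stand for weaker inhibition and lower numbers for stronger inhibition), compound 1 `COc1cccc(N2C(=O)COc3ccc(-c4cnc(Cl)c(NS(=O)(=O)c5ccc(F)cc5)c4)cc32)c1` gives only a limit of the assay, > 40000 nM. Compound 2 `CC(C)N1C(=O)COc2ccc(-c3cnc(Cl)c(NS(=O)(=O)c4ccc(F)cc4)c3)cc21` gives 25500 nM in this assay. The change between them is isopropyl in place of 3-methoxyphenyl on an amide-type nitrogen in a ring, and its size is an at least 1.5-fold lower number from compound 1 to compound 2 (0.19 log units; that floor lies within the scatter); the starting point is the limit described by the limit of > 40000 nM in this assay, at which 2 of the 3 values shown sit. Compound 3 `COc1cccc(N2C(=O)COc3ccc(-c4cccc(NS(=O)(=O)c5ccc(F)cc5)c4)cc32)c1` sits on a different core; how the two cores differ is not broken down here. In this assay compound 3 gives only a limit, > 40000 nM. Compound 4 `CC(C)N1C(=O)COc2ccc(-c3cccc(NS(=O)(=O)c4ccc(F)cc4)c3)cc21` carries the same change as before, (isopropyl in place of 3-methoxyphenyl on an amide-type nitrogen in a ring), at the same place. The step is expected to be an at least 1.4-fold lower number from compound 3 to compound 4 (0.15 log units; that floor lies within the scatter) because the same change gave an at least 1.5-fold lower number from compound 1 to compound 2 (0.19 log units; that floor lies within the scatter). Compound 4 is therefore estimated at 28000 nM, most likely between 12000 nM and 40000 nM, with a real chance that the assay again reports only a limit.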

Compound 4, half-maximal inhibitory concentration: > 40000 nM
Compound 4: only a limit was reported; the forecaster's own chance of this, stated with the estimate: 45%; at least 1.4-fold (0.15 log units) between middle value and limit.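

Compound 3 and compound 4 both give only a limit of the assay, so the step between them, isopropyl in place of 3-methoxyphenyl, cannot be read from this pair: the limit of > 40000 nM in this assay, at which 3 of the 4 values shown sit.

The compounds shown leave open whether this change has any effect on the core of compound 3, and whether its effect matches that seen on the core of compound 1.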